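Vinyl for methyl on the chain at the aromatic nitrogen

The compounds below may be only part of what the source reports. "The series", "measured", "known", "first", "only" and "open" are said of these compounds alone.

Compound 2 `CCn1c(SCC(=O)Nc2ccc(C(C)=O)cc2)nnc1-c1cc(OC)c(OC)c(OC)c1` gives 54% in a functional assay on the whole organism (strain albino) for inhibition, with Rattus norvegicus as the target, read by paw edema, with stated times of 30 min and 3 h, at a dose of 0.28 mmol/kg by the oral route (on this read-out higher numbers stand for more inhibition at the one dose given (going by the name of the read-out) and lower numbers for less inhibition), the low end of three numbers that all sit within the usual scatter of one another: compound 3 `COc1ccc(-c2nnc(SCC(=O)Nc3ccc(C(C)=O)cc3)n2-c2ccccc2)cc1` gives 58% and compound 1 `CCn1c(SCC(=O)Nc2ccc(C(C)=O)cc2)nnc1-c1ccc(OC)c(OC)c1` gives 62%. Among the compounds with values here, the one single-point step in hand, a number 8 percentage points lower from compound 1 to compound 2 (within the scatter), concerns methoxy in place of hydrogen on an aromatic carbon and does not touch the saturated chain carbon bound to the aromatic nitrogen. Compound 4 `C=CCn1c(SCC(=O)Nc2ccc(C(C)=O)cc2)nnc1-c1cc(OC)c(OC)c(OC)c1` differs from compound 2 by vinyl in place of methyl on a saturated chain carbon bound to an aromatic nitrogen. Within the data shown here, no measured step bears on this change, and the series shows no movement beyond scatter, so the expected step is no change at the digits printed from compound 2 to compound 4 (within the scatter), none beyond the scatter. Compound 4 is estimated at 54%, with a range of 40% to 68%.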

Compound 4, a percentage reported as inhibition, in the whole organism at one dose (the size of the read-out at that dose, not a potency): 55%
The estimate for compound 4 lay 1 percentage points below the measured number, within the range that was stated.
By their numbers in this assay, from the lowest: compounds 2, 4, 3 and 1 (each within the scatter of the next).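

In this assay, the step at this position reads a number 1 percentage points higher from compound 2 to compound 4 (within the scatter), so vinyl in place of methyl on a saturated chain carbon bound to an aromatic nitrogen, or ethyl to allyl, leaves the inhibition at the one dose given within the scatter. The added double bond and extra carbon therefore show no separable effect on this read-out in the context of compound 2. No measured evidence bears on why this step is so small.

Open, as far as these compounds go, is how a longer chain such as butyl, or a chain ending in an amine, would read at this position. Also open, from the compounds shown here alone, is whether the same step would hold on the core of compound 1.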